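A Chlorothiophene for a Methylthiophene in DU-145 Cytotoxicity

A few compounds are considered here, and "the series" means these few. Any claim that something is new, unique, unknown or untested is made for them only; others in the source may bear on it.

compound 1, `Cc1ccsc1-c1cc(-c2ccco2)cc(-c2ccc(Cl)cc2)n1`: 26700 nM
compound 2, `Cc1ccsc1-c1cc(-c2ccoc2)cc(-c2ccco2)n1`: 30400 nM
compound 3, `Clc1ccc(-c2cc(-c3ccco3)cc(-c3ccc(Cl)s3)n2)cc1`: 14800 nM

Three compounds were measured in a functional assay on DU-145 cells (Homo sapiens) for cytotoxicity, read by ELISA, with a stated time of 4 days; a lower number here means a stronger inhibitor, a higher number a weaker inhibitor. Compound 1 gives 26700 nM and compound 2 gives 30400 nM; these two lie within the scatter of each other, and the difference between their cores is not broken down here. Compound 3 differs from compound 1 in one place, (5-chlorothiophen-2-yl in place of 3-methylthiophen-2-yl on an aromatic carbon), and this change brought a 1.8-fold lower number from compound 1 to compound 3 (0.26 log units; within the scatter). Compound 3 also shows a lower number than compound 2 does.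

Compound 4, `Clc1ccc(-c2cc(-c3ccoc3)cc(-c3ccco3)n2)s1`, is not yet measured. It carries the same kind of change relative to compound 2, (5-chlorothiophen-2-yl in place of 3-methylthiophen-2-yl on an aromatic carbon); the surroundings differ, since in compound 1 the place is meta to a 4-chlorophenyl group and meta to a furan-2-yl group, whereas in compound 2 it is meta to a furan-2-yl group and meta to a furan-3-yl group. Among the compounds with values here, a step of about a 1.7-fold lower number from compound 2 to compound 4 (0.23 log units; within the scatter) is expected, resting on the one earlier instance, a 1.8-fold lower number from compound 1 to compound 3 (0.26 log units; within the scatter), which itself lay within the scatter. Compound 4 is therefore estimated at 18000 nM in this assay, with a likely range from 8000 nM to 40000 nM.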

Compound 4, half-maximal inhibitory concentration: 17200 nM
The estimate for compound 4 lay 1.0-fold (0.02 log units) above the measured number; the measured number falls inside the stated range.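

In this assay, the exchange of 3-methylthiophen-2-yl for 5-chlorothiophen-2-yl gave a 1.8-fold lower number from compound 2 to compound 4 (0.25 log units; within the scatter), and this step closely matches the one seen earlier on the other core: the same change on two cores in this assay, a 1.8-fold lower number (0.26 log units; within the scatter) from compound 1 to compound 3 and a 1.8-fold lower number (0.25 log units; within the scatter) from compound 2 to compound 4, 1.0-fold (0.01 log units) apart, within the scatter of two such steps This shows that, across these two cores, the exchange carried over with much the same size even though the groups around that place differ. It does not show that the change itself has a real effect, since neither step on its own stands clear of the scatter, nor do two instances establish a rule for other cores in the series.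

All the groups on the central ring in the compounds shown are aromatic rings, which leaves open how the same exchange behaves when a furan-2-yl group gives way to an amine or a carboxylic acid. From the compounds shown here alone, it also remains open whether bromine or a nitrile in place of the chlorine on the thiophene would give a step of similar size.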